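Fluorination of a diarylmethane linker in a glutamate receptor series

The source may report more compounds than this note shows. Statements on the series, on what has been measured and on what is new or still open speak of the compounds shown alone.

Measured so far:
Compound 1, `CCS(=O)(=O)N(Cc1cccnc1)c1ccc(C(=O)c2ccccc2)cc1`, 4200 nM
Compound 2, `C=C(c1ccccc1)c1ccc(N(Cc2cccnc2)S(=O)(=O)CC)cc1`, 780 nM
Compound 3, `CCS(=O)(=O)N(Cc1cccnc1)c1ccc(Cc2ccccc2)cc1`, 1600 nM

The three measured compounds share one core and differ only in the bridge joining the two aromatic rings. In an assay on isolated protein with metabotropic glutamate receptor 2 (Homo sapiens) as the target (on this read-out higher numbers stand for an effect only at larger amounts of compound and lower numbers for an effect already at smaller amounts), compound 1 gives 4200 nM, compound 2 gives 780 nM and compound 3 gives 1600 nM. Compound 3 thus stands second of the three: a 2.1-fold higher number from compound 2 to compound 3 (0.31 log units; beyond the scatter), while a 2.6-fold lower number from compound 1 to compound 3 (0.42 log units; beyond the scatter).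

Compound 4, `CCS(=O)(=O)N(Cc1cccnc1)c1ccc(C(F)c2ccccc2)cc1`, is not yet measured. It differs from compound 3 by fluoro in place of hydrogen on a saturated chain carbon bound to two aromatic carbons. Within the data shown here, no measured step replaces a hydrogen with fluorine at this position, so the only guidance comes from the bridge variations: a 5.4-fold lower number from compound 1 to compound 2 (0.73 log units; beyond the scatter), a 2.6-fold lower number from compound 1 to compound 3 (0.42 log units; beyond the scatter) and a 2.1-fold higher number from compound 2 to compound 3 (0.31 log units; beyond the scatter), all modest. A single fluorine on the same bridge is a smaller alteration than any of those, so a step at or near the scatter is expected in this assay, with no clear direction.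

Compound 4 is therefore estimated at 1400 nM, within 500 nM to 4000 nM, which corresponds to an expected step of a 1.1-fold lower number from compound 3 to compound 4 (0.06 log units; within the scatter).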

Compound 4, half-maximal effective concentration: > 30000 nM
Compound 4 ended at the assay's limit (the forecaster's own chance of this, stated with the estimate: 5%); at least 21-fold (1.33 log units) between middle value and limit.
By their numbers in this assay, from the lowest: compound 2; then compound 3; then compound 1. At a limit, above all of these: compound 4.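

Compound 4 stands at a limit of the assay, not at a number: the limit of > 30000 nM in this assay, at which 1 of the 4 values shown sits. The benzoyl, 1-phenylethenyl and benzyl bridges had moved the number only modestly, so this position had seemed to accept changes, yet fluoro in place of hydrogen on a saturated chain carbon bound to two aromatic carbons, a change of a single heavy atom, gives an at least 18-fold higher number from compound 3 to compound 4 (1.27 log units; beyond the scatter). Among these compounds, the gap also holds against the other two bridges, with an at least 38-fold higher number from compound 2 to compound 4 (1.58 log units; beyond the scatter) and an at least 7.1-fold higher number from compound 1 to compound 4 (0.85 log units; beyond the scatter), so the smallest structural change in the set, measured from the benzyl bridge of compound 3, goes with a step larger than any among the earlier compounds.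

The compounds shown leave open whether this step belongs to fluoro itself or would follow any replacement of that hydrogen, since no hydroxyl, methyl, amine or second fluoro on the same carbon stands beside compound 4 for comparison. Going by these compounds, how far compound 4 really lies past the limit also remains unknown, so each of these steps gives only a lower bound on the true size of the change.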